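The source may report more compounds than this note shows. Statements on the series, on what has been measured and on what is new or still open speak of the compounds shown alone.

Working notes on the series, around the step from compound 2 to compound 4.

Among the measured compounds shown here, compound 1 `O=C(c1ccc(F)c(F)c1)N1CC(c2nc(-c3cccc(F)c3)no2)C1` is the only member with a numerical result: in an assay on HEK293 cells for positive allosteric modulation of metabotropic glutamate receptor 5 (Homo sapiens), read by FLIPR (a higher number here means that more compound is needed for the effect, a lower number that less compound is needed), compound 1 gives 3200 nM. Compound 2 `O=C(c1cccc(F)c1)N1CC(c2nc(-c3cccc(Cl)c3)no2)C1` differs from compound 1 in both aromatic rings. In this assay compound 2 returns only the limit > 10000 nM, so where compound 2 stands is known as a bound and not as a number. Compound 3 `Cc1cccc(-c2noc(C3CN(C(=O)c4cccc(F)c4)C3)n2)c1` likewise returns only the limit > 10000 nM in this assay. For the measured compounds named here, the one measured single-point step, methyl in place of chloro on an aromatic carbon, a step that the two limits leave unreadable from compound 2 to compound 3, cannot be sized, since both of its ends sit at the limit of > 10000 nM in this assay, at which 2 of the 3 values shown sit.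

Compound 4 `COC1CCCN(C(=O)N2CC(c3nc(-c4cccc(Cl)c4)no3)C2)C1` is the compound still to be measured. It differs from compound 2 by 3-methoxypiperidin-1-yl in place of 3-fluorophenyl on a carbonyl carbon. Going by the values given here, no measured step touches the carbonyl side of the shared core, so nothing measured bears directly on this change; what is known is only that compound 2 sits at the limit. Compound 4 is therefore expected to remain near that limit, with an estimate of 9000 nM spanning 2500 nM to 30000 nM. The implied step an at least 1.1-fold lower number from compound 2 to compound 4 (0.04 log units; that floor lies within the scatter) is expected to stay within the scatter, with a limit result the likelier outcome.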

Compound 4, half-maximal effective concentration: > 10000 nM
Compound 4 gave a limit, no number; the forecaster's own chance of this, stated with the estimate: 60%; middle value at least 1.1-fold (0.04 log units) away from the limit.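

In this assay compound 4 gives > 10000 nM as a limit and not a number. Compound 2 also stands at a limit, so no step can be read between compound 2 and compound 4: the limit of > 10000 nM in this assay, at which 3 of the 4 values shown sit.

The compounds shown leave open the size and direction of the step for 3-methoxypiperidin-1-yl in place of 3-fluorophenyl on a carbonyl carbon.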